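The source may report more compounds than this note shows. Statements on the series, on what has been measured and on what is new or still open speak of the compounds shown alone.

Compound 1 `Cc1c(OCCCCOc2ccccc2C(=O)O)ccc(C(=O)CC2CCCC2)c1C` gives 28% in an assay on HEK293 cells for positive allosteric modulation of metabotropic glutamate receptor 3 (Rattus norvegicus), read by thallium flux, with a stated time of 2.5 min; on this read-out lower numbers stand for smaller maximal responses and higher numbers for larger maximal responses.
Compound 2 `Cc1c(OCCCCOc2ccccc2C(=O)O)ccc(C(=O)CC2CCCC2)c1O` gives 32.9% in this assay.
Compound 3 `Cc1c(OCCCCOc2ccc(C(=O)O)cc2Cl)ccc(C(=O)CC2CCCC2)c1O` gives 27.4% in this assay.

Among these three numbers compound 1 sits in the middle, with compound 3 nearest to it and compound 2 furthest, and both gaps lie within the scatter, so the three compounds are effectively indistinguishable here. Compound 4 `Cc1c(OCCCCOc2ccc(F)c(C(=O)O)c2)ccc(C(=O)CC2CCCC2)c1C` differs from compound 1 in one place: 3-carboxy-4-fluorophenyl in place of 2-carboxyphenyl on an oxygen on a saturated carbon. The most comparable measured step is a number 5.5 percentage points lower from compound 2 to compound 3 (within the scatter), where 4-carboxy-2-chlorophenyl replaced 2-carboxyphenyl on the same oxygen on a saturated carbon and nothing beyond the scatter followed. The step of a number 4.9 percentage points higher from compound 1 to compound 2 (within the scatter) touches a different part of the shared core and also stayed within the scatter. No step beyond the scatter is therefore expected, no change at the digits printed from compound 1 to compound 4 (within the scatter). Compound 4 is expected to give 28%, within 17% to 40%.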

Compound 4, largest response reached (reported as percent of maximum), in percent of the reference or control that the assay uses: 12.6%
Beside the measured number, compound 4's estimate is 15.4 percentage points above it; measured number below the stated range.
By their numbers in this assay, from the lowest: compound 4; then compounds 3, 1 and 2 (each within the scatter of the next).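

Swapping to 3-carboxy-4-fluorophenyl on this oxygen on a saturated carbon gives a number 15.4 percentage points lower from compound 1 to compound 4 (beyond the scatter) in this assay, the first step among these compounds to pass the scatter, whereas 4-carboxy-2-chlorophenyl at the same place gave only a number 5.5 percentage points lower from compound 2 to compound 3 (within the scatter). Different carboxyphenyl groups at this place are therefore not interchangeable. Nothing measured here explains the drop.

The fluorine and the placement of the carboxy group change together, so the compounds shown leave open which of them matters. They also leave open how a nitrile in place of that fluorine would behave.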